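Linker change from benzamide to cinnamamide in compound 4

The source may hold more compounds than are shown below. What is called first, only, known or untested is meant among the compounds shown, and "the series" means these compounds.

Compound 3 `Nc1ccccc1NC(=O)c1ccc(Cn2cnc3c(Nc4cccc(OC(F)(F)F)c4)nc(Cl)nc32)cc1` sits at the bottom of the three numbers in hand: in a functional assay on HepG2 cells (Homo sapiens) for antiproliferative activity, read by CCK-8 assay, with a stated time of 72 h, tested at 8 uM (a higher number here means a stronger effect of the compound at the concentration tested, a lower number a weaker effect), compound 3 gives 31.2%. The nearest neighbour is compound 2 `Nc1ccccc1NC(=O)/C=C/c1ccc(Cn2cnc3c(NCc4ccccc4)nc(Cl)nc32)cc1`, for which this assay returns 37.7%, a gap that lies within the scatter. Compound 1 `Nc1ccccc1NC(=O)/C=C/c1ccc(Cn2cnc3c(Nc4cccc(Cl)c4)nc(Cl)nc32)cc1` stands furthest away, with 49.3% in this assay, a gap beyond the scatter. Among the compounds with values here, the one measured step, a number 11.6 percentage points lower from compound 1 to compound 2 (beyond the scatter), concerns the substituent on the ring nitrogen of the shared core and not the amide side.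

Compound 4 `Nc1ccccc1NC(=O)/C=C/c1ccc(Cn2cnc3c(Nc4cccc(OC(F)(F)F)c4)nc(Cl)nc32)cc1` keeps the trifluoromethoxyphenyl group of compound 3 and alters the amide side: 2-((2-aminophenyl)carbamoyl)ethenyl in place of (2-aminophenyl)carbamoyl on an aromatic carbon. Within the data shown here, no measured pair isolates this change, so nothing bears on it directly. What can be said is that compound 1 and compound 2 both carry the longer 2-((2-aminophenyl)carbamoyl)ethenyl side and both read higher than compound 3, though their amine substituents differ as well.

On that thin basis the expected step of a number 10.8 percentage points higher from compound 3 to compound 4 (beyond the scatter) is a modest rise, with wide uncertainty. Compound 4 is estimated to give 42% in this assay, expected between 28% and 58%.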

Compound 4, a percentage reported as inhibition, at one concentration (the size of the read-out at that concentration, not a potency): 37.6%
For compound 4 the middle estimate is 4.4 percentage points above the measured one, and the stated range covers the measured number.
By their numbers in this assay, from the lowest: compounds 3, 4 and 2 (each within the scatter of the next); then compound 1.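

Working notes on the series: compound 3 and compound 4 form the first pair that isolates the amide side. In this assay, 2-((2-aminophenyl)carbamoyl)ethenyl in place of (2-aminophenyl)carbamoyl, on an aromatic carbon para to a large group, gives a number 6.4 percentage points higher from compound 3 to compound 4 (within the scatter), so with the 3-(trifluoromethoxy)phenyl group held fixed, this change is not resolved from the scatter.

With the longer side held fixed, trifluoromethoxy in place of chloro on an aromatic carbon gives a number 11.7 percentage points lower from compound 1 to compound 4 (beyond the scatter), while 3-(trifluoromethoxy)phenyl in place of benzyl on the nitrogen gives a number 0.1 percentage points lower from compound 2 to compound 4 (within the scatter); among these three compounds with the longer side, compound 1 alone stands apart from the other two. No available evidence accounts for either the small amide-side step or the separation of compound 1.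

Within the data shown here, whether the amide-side step reads the same with 3-chlorophenyl or benzyl on the nitrogen remains open, since the single isolating pair carries only 3-(trifluoromethoxy)phenyl. Also open, going by these compounds, is how a longer chain in place of the ethenyl link, or methoxy in place of trifluoromethoxy on the aromatic ring, would read in this assay.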